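Triazole in Place of the Azide on a Shorter Chain

The source may report more compounds than this note shows. Statements on the series, on what has been measured and on what is new or still open speak of the compounds shown alone.

Compound 1 `[N-]=[N+]=NCCCCCCCCCN[C@@H]1[C@@H](O)[C@@H](O)[C@H](O)[C@H]2COC(=O)N21`: 19300 nM
Compound 2 `CC(C)(C)OC(=O)NCCCCCCCCCN[C@@H]1[C@@H](O)[C@@H](O)[C@H](O)[C@H]2COC(=O)N21`: 30700 nM

For the measured compounds named here, in an assay on lysate for inhibition of lysosomal alpha-mannosidase (Homo sapiens), read by reporter gene assay and fluorescence, with a stated time of 60 min (a lower number here means a stronger inhibitor, a higher number a weaker inhibitor), compound 1 gives 19300 nM, the lower of the two numbers measured so far. Compound 2 gives 30700 nM in this assay. Going by the values given here, the one measured step reads a 1.6-fold higher number from compound 1 to compound 2 (0.20 log units; within the scatter), so the difference between these two compounds is within the scatter. Compound 3 `CCCc1cn(CCCCCCN[C@@H]2[C@@H](O)[C@@H](O)[C@H](O)[C@H]3COC(=O)N32)nn1` is not yet measured and differs from compound 1 in one place: 4-propyl-1H-1,2,3-triazol-1-yl in place of 3-azidopropyl on a saturated chain carbon, six bonds along the chain from an amine nitrogen. Among the compounds with values here, no measured step matches this change. Within the data shown here, the only step available, from compound 1 to compound 2, altered the group at the far end of the chain and stayed within the scatter, which hints that the chain end tolerates variation, though the shortened chain in compound 3 has no counterpart among the measured compounds. A step of a 1.3-fold lower number from compound 1 to compound 3 (0.11 log units; within the scatter) is expected, with no direction beyond the scatter. Compound 3 is estimated at 15000 nM, in a range from 4000 nM to 60000 nM.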

Compound 3, half-maximal inhibitory concentration: 17300 nM
Compound 3: the middle estimate sits 1.2-fold (0.06 log units) below what was measured, within the range that was stated.
By their numbers in this assay, from the lowest: compounds 3, 1 and 2 (each within the scatter of the next).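

In this assay, 4-propyl-1H-1,2,3-triazol-1-yl in place of 3-azidopropyl, on a saturated chain carbon, six bonds along the chain from an amine nitrogen, gives a 1.1-fold lower number from compound 1 to compound 3 (0.05 log units; within the scatter) and so stays within the scatter. The earlier step had only exchanged one open-chain group for another, whereas this one shows that a group with one five-membered aromatic ring with 3 hetero atoms can stand here with no change beyond the scatter. Nothing available explains this result.

No step among the compounds shown lies beyond the scatter, so they do not reveal what at this position would move the number. On these data alone, it remains open whether an amine or a carboxylic acid in place of the propyl on the triazole, or a longer chain carrying the triazole, would do so.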